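The source may report more compounds than this note shows. Statements on the series, on what has been measured and on what is new or still open speak of the compounds shown alone.

The study brings together four compounds built on a shared pattern of change. Compound 1 `CC1=C(C(=O)OC(C)(C)C)C(c2ccsc2)NC(=O)N1` and compound 2 `CC1=C(C(=O)OCc2ccccc2)C(c2ccsc2)NC(=O)N1` differ by benzyl in place of tert-butyl on an oxygen next to a carbonyl group. In an assay on membranes from CHO cells for displacement of a labelled ligand from adenosine receptor A1 (Homo sapiens), read by scintillation counting, with a stated time of 60 min, tested at 1 uM (on this read-out lower numbers stand for less inhibition and higher numbers for more inhibition at the one concentration tested (going by the name of the read-out)), compound 1 gives 15%, while compound 2 gives 57%, so that a number 42 percentage points higher from compound 1 to compound 2 (beyond the scatter). Compound 3 `CC1=C(C(=O)OC(C)(C)C)C(c2cccs2)NC(=O)N1C` differs from compound 1 in more than one place; the difference between the two cores is not broken down here. In this assay compound 3 gives 18%, a number within the scatter of that of compound 1. Compound 4 `CC1=C(C(=O)OCc2ccccc2)C(c2cccs2)NC(=O)N1C` has not yet been measured. It differs from compound 3 by benzyl in place of tert-butyl on an oxygen next to a carbonyl group, which is the same change as that from compound 1 to compound 2, made at the same place. The expectation for compound 4 rests on the step of a number 42 percentage points higher from compound 1 to compound 2 (beyond the scatter) and on compound 3 giving 18%, a number within the scatter of that of compound 1. A step of similar size is therefore expected, namely a number 42 percentage points higher from compound 3 to compound 4 (beyond the scatter). Compound 4 is estimated at 60% in this assay, expected to fall between 38% and 80%.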

Compound 4, a percentage reported as inhibition, at one concentration (the size of the read-out at that concentration, not a potency): 50%
Beside the measured number, compound 4's estimate is 10 percentage points above it; low and high end bracket the measured number.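

Carried to the core of compound 3, benzyl in place of tert-butyl on an oxygen next to a carbonyl group gives, in this assay, a number 32 percentage points higher from compound 3 to compound 4 (beyond the scatter). The step on this core can be set beside the one on the core of compound 1, and the two agree in direction and do not differ in size: the same change on two cores in this assay, a number 42 percentage points higher (beyond the scatter) from compound 1 to compound 2 and a number 32 percentage points higher (beyond the scatter) from compound 3 to compound 4, 10 percentage points apart, within the scatter of two such steps. This shows that the change carried over between these two cores, as read at a single concentration, but it gives no potency, does not tell which part of the difference between the cores could matter, and says nothing about whether the step would hold on any further core.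

The compounds shown carry only tert-butyl and benzyl on this oxygen, so it stays open how a methyl group, an ethyl group or a longer chain would read there. On these data alone, whether an amine or a carboxylic acid on the ring of the benzyl group would keep the step is equally open.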